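The source may report more compounds than this note shows. Statements on the series, on what has been measured and on what is new or still open speak of the compounds shown alone.

Measured so far:
compound 1, `COc1cnc(-c2ccccn2)nc1NCc1ccccc1Cl`: 704 mL/min/kg
compound 2, `COc1cnc(-c2ccccn2)nc1NCc1ccccc1C(F)(F)F`: 619 mL/min/kg

In an in vitro ADME assay on microsomes from liver (Mus musculus) for metabolic stability, read by LC-MS, tested at 0.05 uM (on this read-out lower numbers stand for slow clearance and higher numbers for fast clearance), compound 1 stands highest of the two numbers measured, with compound 2 as its nearest neighbour; the step of a 1.1-fold lower number from compound 1 to compound 2 (0.06 log units; within the scatter) shows the two as indistinguishable. Compound 3, `COc1cnc(-c2ccccn2)nc1NCc1ccccc1F`, differs from compound 1 in one place: fluoro in place of chloro on an aromatic carbon. Among the compounds with values here, the single measured step, trifluoromethyl in place of chloro on an aromatic carbon from compound 1 to compound 2, is the only comparison that touches the same aromatic carbon, and it was a 1.1-fold lower number from compound 1 to compound 2 (0.06 log units; within the scatter). Within the data shown here, no measured pair exchanges chloro for fluoro directly. On that basis the account expects compound 3 to show no step beyond the scatter, a 1.1-fold lower number from compound 1 to compound 3 (0.03 log units; within the scatter). The estimate for compound 3 is 650 mL/min/kg, with a range from 330 mL/min/kg to 1250 mL/min/kg.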

Compound 3, clearance: 672 mL/min/kg
Beside the measured number, compound 3's estimate is 1.0-fold (0.01 log units) below it; the measured number falls inside the stated range.
By their numbers in this assay, from the lowest: compounds 2, 3 and 1 (each within the scatter of the next).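

In this assay the change from 2-chlorophenyl to 2-fluorophenyl gives a 1.0-fold lower number from compound 1 to compound 3 (0.02 log units; within the scatter) and the exchange of trifluoromethyl for fluoro gives a 1.1-fold higher number from compound 2 to compound 3 (0.04 log units; within the scatter) at the same aromatic carbon. Within the data shown here, with the earlier step, all three pairs among compound 1, compound 2 and compound 3 now lie within the scatter, so this read-out does not separate chloro, trifluoromethyl and fluoro at this position, where the earlier compounds offered only one comparison. Nothing measured here offers an explanation for this sameness.

Going by these compounds, it remains open whether an amine, a hydroxyl or a carboxylic acid on this aromatic carbon would give a step beyond the scatter. On these data alone, it is also open whether the same three groups would read alike elsewhere on this ring or on a different core.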